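This account rests on a few compounds, and the source may have more. Where it says the series, first, only, none or still open, it means among the compounds named here.

Two amides of the shared core have been measured. Compound 1 `Cc1ccc(-c2csc(NC(=O)COc3ccccc3C)n2)cc1` gives 54900 nM in a functional assay on Ehrlich cells (Mus musculus) for cytotoxicity, read by trypan blue exclusion, with a stated time of 48 h; a higher number here means a weaker inhibitor, a lower number a stronger inhibitor. Compound 2 `Cc1ccc(-c2csc(NC(=O)COc3ccccc3C(C)C)n2)cc1` gives 42800 nM in this assay. Within the data shown here, the only measured step, a 1.3-fold lower number from compound 1 to compound 2 (0.11 log units; within the scatter), is the sole guide the series offers. Compound 2 holds the lowest of the two numbers, but its nearest neighbour compound 1 sits within the scatter of it, so no order between the two can be claimed.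

Compound 3 `CC(C)c1ccccc1OCC(=O)Nc1nc(-c2ccc(Cl)cc2)cs1` remains to be measured. It differs from compound 2 by chloro in place of methyl on an aromatic carbon. Among the measured compounds shown here, no measured pair exchanges methyl for chloro, and the one step in hand, a 1.3-fold lower number from compound 1 to compound 2 (0.11 log units; within the scatter), concerns a different position and stays within the scatter. The numbers therefore give no ground for expecting a shift beyond the scatter in this assay. The expected step is a 1.1-fold lower number from compound 2 to compound 3 (0.03 log units; within the scatter). For the measured compounds named here, compound 3 is accordingly estimated at 40000 nM, with a range from 15000 nM to 110000 nM that is kept wide because the only comparable step, a 1.3-fold lower number from compound 1 to compound 2 (0.11 log units; within the scatter), does not test this exchange.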

Compound 3, half-maximal inhibitory concentration: 49800 nM
Estimate against measurement, compound 3: 1.2-fold (0.10 log units) below, within the range that was stated.
By their numbers in this assay, from the lowest: compounds 2, 3 and 1 (each within the scatter of the next).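

In this assay, among these compounds, the change from 4-methylphenyl to 4-chlorophenyl gives a 1.2-fold higher number from compound 2 to compound 3 (0.07 log units; within the scatter) and is the first change read at this position, on an aromatic carbon para to a large group. Chloro in place of methyl at this carbon therefore moves the number no further than the scatter, so the two groups cannot be told apart here with the isopropyl group held constant. Among the compounds shown here, the step gives no order among the compounds, and no available evidence bears on the result.

The compounds shown leave open whether any group at this carbon can shift the number beyond the scatter, and an amine or a carboxylic acid in place of chloro would put that to a sharper test. They also leave open whether the chloro and methyl groups remain equivalent when the isopropyl group on the other aromatic ring is replaced by a different group, such as a longer chain.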